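The source may report more compounds than this note shows. Statements on the series, on what has been measured and on what is new or still open speak of the compounds shown alone.

Measured so far:
- compound 1 `CCOC(=O)c1c(-c2cccc(Oc3ccccc3)c2)[nH]c2cc(OC)c(OC)cc2c1=O` — > 22000 nM
- compound 2 `CCOC(=O)c1c(-c2cccc(Oc3ccccc3)c2)[nH]c2cc(Cl)c(OC)cc2c1=O` — > 22000 nM
- compound 3 `CCOC(=O)c1c(-c2cccc(-c3ccccc3)c2)[nH]c2cc(Cl)c(Cl)cc2c1=O` — > 22000 nM

In an ADME assay on HEK293 cells (Homo sapiens) for cytotoxicity, read by luminescence, with a stated time of 72 h (on this read-out higher numbers stand for an effect only at larger amounts of compound and lower numbers for an effect already at smaller amounts), compound 1 reaches only a limit, > 22000 nM, and not a number. In this assay compound 2 likewise gives a limit, > 22000 nM. In this assay compound 3 also gives a limit, > 22000 nM. Going by the values given here, all three values therefore sit at the limit of > 22000 nM in this assay, at which 3 of the 3 values shown sit, so nothing among the measured compounds separates one from another in this read-out.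

The change from compound 2 to compound 1 is methoxy in place of chloro on an aromatic carbon. Its step, a step that the two limits leave unreadable from compound 2 to compound 1, cannot be read, since both ends are limits. The difference between the core of compound 2 and the core of compound 3 is not broken down here.

Compound 4 `CCOC(=O)c1c(-c2cccc(-c3ccccc3)c2)[nH]c2cc(OC)c(Cl)cc2c1=O` is not yet measured. It differs from compound 3 by methoxy in place of chloro on an aromatic carbon. Among the compounds with values here, this is the same kind of change as the one from compound 2 to compound 1, not the same: in compound 4 the entering methoxy is ortho to a chloro group (1 heavy atom), whereas in compound 1 it is ortho to a methoxy group (2 heavy atoms).

For compound 4 the expected step from compound 3 is a step that the limit leaves unreadable from compound 3 to compound 4, which is to say no readable change, because every value shown so far sits at the limit of > 22000 nM in this assay, at which 3 of the 3 values shown sit. Compound 4 is accordingly expected to give about 30000 nM in this assay, with a range from 15000 nM to 80000 nM, and most likely only a limit again.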

Compound 4, half-maximal effective concentration: > 22000 nM
Compound 4: a limit, no number; the forecaster's own chance of this, stated with the estimate: 85%; the middle value lies beyond the limit too.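

In this assay compound 4 gives > 22000 nM, which is a limit and not a number. No step can be read between compound 3 and compound 4, because both ends are limits: the limit of > 22000 nM in this assay, at which 4 of the 4 values shown sit.

The compounds shown leave open at what concentration compound 1, compound 2, compound 3 or compound 4 would reach a half-maximal effect, and whether methoxy in place of chloro shifts that concentration.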